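A few compounds are considered here, and "the series" means these few. Any claim that something is new, unique, unknown or untested is made for them only; others in the source may bear on it.

Compound 1, with the structure `CCCCn1nc(C)c2c(C)cc(=O)oc21`, compound 2, with the structure `CCCCCn1nc2oc(=O)cc(C)c2c1C`, and compound 3, with the structure `Cc1cc(O)oc2nncc1-2`, were examined in a functional assay on the whole organism with Mus musculus as the target, in the writhing test; a higher number here means that more compound is needed for the effect, a lower number that less compound is needed. Compound 1 reached only a limit in this assay and gave no number, namely > 100 mg/kg, which is also recorded as the limit of > 100 mg/kg in this assay, at which 1 of the 3 values shown sits. Compound 2 gave 60.6 mg/kg in this assay. Compound 3 gave 40.6 mg/kg in this assay, and since compound 2 lies within the usual scatter of that value, the two cannot be separated on the evidence in hand; compound 3 thus stands among the measured members of the series, not apart from them.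

Compound 4, with the structure `Cc1cc(O)oc2nnc(CC(=O)O)c1-2`, has not yet been measured. It differs from compound 3 in one place: carboxymethyl in place of hydrogen on an aromatic carbon. Among the compounds with values here, no measured pair in this set shows what such a change does, so nothing in the data points to a shift in either direction. The step from compound 3 to compound 4 is therefore expected to lie within the scatter, as a 1.2-fold lower number from compound 3 to compound 4 (0.06 log units; within the scatter). Compound 4 is estimated to give 35 mg/kg in this assay, with a range from 12 mg/kg to 100 mg/kg.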

Compound 4, dose for half-maximal effect: > 100 mg/kg
Compound 4: only a limit was reported (the forecaster's own chance of this, stated with the estimate: 15%); middle value at least 2.8-fold (0.45 log units) from the limit.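

Within the data shown here, the step from hydrogen to carboxymethyl gives the first reading on this position, an aromatic carbon of the five-membered aromatic ring with 2 nitrogen, next to the ring nitrogen. In this assay, the change gives an at least 2.4-fold higher number from compound 3 to compound 4 (0.39 log units; beyond the scatter), so this carbon does not accept every substituent without consequence, although this single pair speaks only for carboxymethyl. The value of compound 4 is a limit and not a number, so the step has a lower bound but no measured size: the limit of > 100 mg/kg in this assay, at which 2 of the 4 values shown sit.

The compounds shown do not separate the contribution of the carboxylic acid from that of the added chain, as they include no methyl ester, primary amide or simple ethyl group on this carbon. They also leave open whether a primary amine at the end of the same short chain would give a step of the same direction, and whether carboxymethyl would act alike on a core carrying a butyl or pentyl group on the ring nitrogen.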